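The compounds below may be only part of what the source reports. "The series", "measured", "known", "first", "only" and "open" are said of these compounds alone.

In a functional assay on A549 cells (Homo sapiens) for antiproliferative activity, tested at 1 uM (on this read-out lower numbers stand for less inhibition and higher numbers for more inhibition at the one concentration tested (going by the name of the read-out)), three compounds have been measured so far. Compound 1 `Cc1nn(-c2ccccc2)c(Oc2ccc(Cl)cc2)c1/C=N/OCc1ccc(C(=O)OC(C)(C)C)cc1` gives -6.5%, compound 2 `Cc1nn(C)c(Oc2ccc(Cl)cc2)c1/C=N/OCc1ccc([N+](=O)[O-])cc1` gives 39.6%, and compound 3 `CC(C)c1nn(-c2ccccc2)c(Oc2ccc(Cl)cc2)c1/C=N/OCc1ccc(C(=O)OC(C)(C)C)cc1` gives -10.6%. Compound 3 carries the lowest of the three numbers; compound 1 is nearest to it, within the scatter, while compound 2 is furthest, beyond the scatter. Among the measured compounds shown here, the only measured step between two compounds that differ in a single place is a number 4.1 percentage points lower from compound 1 to compound 3 (within the scatter), a change of an alkyl group on the shared core that stays within the scatter.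

Compound 4 `CC(C)c1nn(-c2ccccc2)c(Oc2ccc(Cl)cc2)c1/C=N/OCc1ccc(C(F)(F)F)cc1` differs from compound 3 in one place: trifluoromethyl in place of tert-butoxycarbonyl on an aromatic carbon. For the measured compounds named here, no measured step touches this part of the molecule, so none bears directly on the change. Going by the values given here, compound 2 differs from compound 3 in more than one place, and its value shows only that compounds of this family can reach clearly higher numbers; it cannot be tied to the group exchanged here. With nothing to point in either direction, the expectation is that compound 4 stays near compound 3 in this assay, with an estimate of 0% and a range from -15% to 20%. The expected step of a number 10.6 percentage points higher from compound 3 to compound 4 (beyond the scatter) is small and uncertain in direction.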

Compound 4, a percentage reported as inhibition, at one concentration (the size of the read-out at that concentration, not a potency): -12.1%
For compound 4 the middle estimate is 12.1 percentage points above the measured one, within the range that was stated.
By their numbers in this assay, from the lowest: compounds 4, 3 and 1 (each within the scatter of the next); then compound 2.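

Replacing tert-butoxycarbonyl with trifluoromethyl on the aromatic carbon, para to a large group, gives a number 1.5 percentage points lower from compound 3 to compound 4 (within the scatter) in this assay. On this isopropyl-bearing core, a larger group with a carbonyl and hydrogen-bond acceptors and a smaller group with neither therefore give numbers within the scatter of each other, so this single exchange gives no sign that the position affects the read-out, although one pair cannot show how the position behaves in general. No measurement available here explains this outcome.

On these data alone, it remains open whether a different kind of group at this position, such as an amine, a carboxylic acid or a longer chain, would move the number beyond the scatter, or whether the same exchange would behave alike on a core carrying methyl instead of isopropyl. Compound 2, at 39.6%, differs from the other compounds in more than one place, so the shown compounds cannot tie its value to any single structural feature.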